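Chain lengthening on the side chain in one antiproliferative series

The source may report more compounds than this note shows. Statements on the series, on what has been measured and on what is new or still open speak of the compounds shown alone.

The series is read in a functional assay on SW480 cells (Homo sapiens) for antiproliferative activity, read by MTT assay, with a stated time of 48 h; on this read-out lower numbers stand for stronger inhibition and higher numbers for weaker inhibition. Compound 1 `CCCC(CCO)n1cnc2c(Cl)nc(F)nc21` gives 17200 nM in this assay, and compound 2 `CCCCC(CCO)n1cnc2c(Cl)nc(F)nc21` gives 13200 nM. The change between them is methyl in place of hydrogen on a saturated chain carbon, four bonds along the chain from an aromatic nitrogen, and it makes a step of a 1.3-fold lower number from compound 1 to compound 2 (0.11 log units; within the scatter). Compound 3 `CCCCCCC[C@@H](CCO)n1cnc2c(Cl)ncnc21` gives 3820 nM in this assay, the lowest number of the three; the difference between the core of compound 1 and the core of compound 3 is not broken down here. Compound 4 `CCCCCCCC[C@@H](CCO)n1cnc2c(Cl)ncnc21` is not yet measured. It differs from compound 3 by methyl in place of hydrogen on a saturated chain carbon, eight bonds along the chain from an aromatic nitrogen, the same kind of change as from compound 1 to compound 2, but at a different place: four bonds along the chain from an aromatic nitrogen in the earlier pair, eight bonds along the chain from an aromatic nitrogen here. For compound 4 a step of a 1.3-fold lower number from compound 3 to compound 4 (0.10 log units; within the scatter) is expected, because a 1.3-fold lower number from compound 1 to compound 2 (0.11 log units; within the scatter) stayed within the scatter for the earlier pair. Compound 4 is therefore estimated at 3000 nM in this assay. For compound 4 the expected range runs from 1400 nM to 6500 nM.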

Compound 4, half-maximal inhibitory concentration: 2330 nM
Compound 4: the middle estimate sits 1.3-fold (0.11 log units) above what was measured; low and high end bracket the measured number.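

In this assay the added methyl makes a step of a 1.6-fold lower number from compound 3 to compound 4 (0.21 log units; within the scatter) and so stays small on this core as well. Carried from one core to the other, the change gives steps that do not differ: the same change on two cores in this assay, a 1.3-fold lower number (0.11 log units; within the scatter) from compound 1 to compound 2 and a 1.6-fold lower number (0.21 log units; within the scatter) from compound 3 to compound 4, 1.3-fold (0.10 log units) apart, within the scatter of two such steps
Neither step shows a real change in the number on its own core, and the two pairs differ in the place of the methyl as well as in the core, so core and place cannot be told apart.

Open, on these data alone, is whether a chain longer than that of compound 4 would move the number beyond the scatter. Also open, as far as these compounds go, is how an amine or a carboxylic acid in place of the hydroxyl would read on either core.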